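Swapping the terminal amine on a kinase-type diaryl ether series

A few compounds are considered here, and "the series" means these few. Any claim that something is new, unique, unknown or untested is made for them only; others in the source may bear on it.

Measured compounds:
compound 1 `COc1cc2c(Oc3ccc(NC(=O)c4nn(-c5ccccc5C)c(=O)cc4C)cc3F)ccnc2cc1OCCCN1CCN(C)CC1`: 3420 nM
compound 2 `COc1cc2c(Oc3ccc(NC(=O)c4nn(-c5ccccc5C(F)(F)F)c(=O)cc4C)cc3F)ccnc2cc1OCCCN1CCCC1`: 210 nM
compound 3 `COc1cc2c(Oc3ccc(NC(=O)c4nn(-c5ccccc5C(F)(F)F)c(=O)cc4C)cc3F)ccnc2cc1OCCCN1CCCCC1`: 210 nM

Compound 3 stands level with compound 2 in a functional assay on NCI-H460 cells (Homo sapiens) for inhibition, read by MTT assay, with a stated time of 72 h (a higher number here means a weaker inhibitor, a lower number a stronger inhibitor), the two sharing the lowest numbers of the three, while compound 1 sits well apart. Going by the values given here, the one measured step between neighbours, no change at the digits printed from compound 2 to compound 3 (within the scatter), shows that exchanging one saturated amine for another at this end of the chain left the number unchanged. Compound 4 `COc1cc2c(Oc3ccc(NC(=O)c4nn(-c5ccccc5C(F)(F)F)c(=O)cc4C)cc3F)ccnc2cc1OCCCN1CCN(C)CC1` carries the change (4-methylpiperazin-1-yl in place of piperidin-1-yl on a saturated chain carbon, three bonds along the chain from an oxygen on an aromatic ring). Among the compounds with values here, the only step that bears on it is the amine swap from compound 2 to compound 3, which was flat, so no shift beyond the scatter is expected in this assay, a 1.3-fold higher number from compound 3 to compound 4 (0.12 log units; within the scatter). Compound 4 is therefore estimated at 280 nM, with a range of 90 nM to 900 nM.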

Compound 4, half-maximal inhibitory concentration: 240 nM
Beside the measured number, compound 4's estimate is 1.2-fold (0.07 log units) above it; the range from low to high includes it.
By their numbers in this assay, from the lowest: compounds 2, 3 and 4 (each within the scatter of the next); then compound 1.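

In this assay, 4-methylpiperazin-1-yl in place of the other saturated rings changes nothing beyond the scatter, with a 1.1-fold higher number from compound 3 to compound 4 (0.06 log units; within the scatter) and a 1.1-fold higher number from compound 2 to compound 4 (0.06 log units; within the scatter) as the two steps, so the second ring nitrogen leaves the number level at this end of the chain. With that amine held fixed, trifluoromethyl in place of methyl on an aromatic carbon gives a 14-fold lower number from compound 1 to compound 4 (1.15 log units; beyond the scatter) and so accounts for the distance of compound 1 from compound 4. No supporting data explain either result.

Still open, as far as these compounds go, is whether morpholine or dimethylamino in place of 4-methylpiperazin-1-yl, or a longer chain, would also stay level.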